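Sulfonyl substituent swap: propyl to phenyl in the series

A few compounds are considered here, and "the series" means these few. Any claim that something is new, unique, unknown or untested is made for them only; others in the source may bear on it.

Compound 3 `CCCS(=O)(=O)NC(=O)c1cc(COc2ccc(-c3ccc(OC)cc3)cc2)c(C)o1` gives 5 nM in an assay on cells for displacement of a labelled ligand from prostaglandin E2 receptor EP4 subtype (Homo sapiens), read by scintillation counting (a lower number here means a stronger inhibitor, a higher number a weaker inhibitor), the second highest of three numbers. Compound 2 `COc1ccc(-c2ccc(OCc3cc(C(=O)NS(=O)(=O)c4cccs4)oc3C)cc2)cc1` gives 3.6 nM, nearest to compound 3 and within the scatter; compound 1 `COc1ccc(-c2ccc(OCc3cc(C(=O)NS(=O)(=O)c4ccccc4)oc3C)cc2)c(C)c1` gives 21 nM, the furthest, beyond the scatter. Compound 4 `COc1ccc(-c2ccc(OCc3cc(C(=O)NS(=O)(=O)c4ccccc4)oc3C)cc2)cc1` is not yet measured; it differs from compound 3 by phenyl in place of propyl on a sulfonyl sulfur. Among the compounds with values here, the one step that bears on it, a 1.4-fold higher number from compound 2 to compound 3 (0.14 log units; within the scatter), exchanged one sulfonyl substituent for another without leaving the scatter, so a move from propyl back to an aromatic ring is expected to produce no step beyond the scatter. For compound 4 the expected value in this assay is 6 nM, with a range of 2 nM to 18 nM, which means an expected step of a 1.2-fold higher number from compound 3 to compound 4 (0.08 log units; within the scatter).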

Compound 4, inhibition constant: 5 nM
Compound 4: the middle estimate sits 1.2-fold (0.08 log units) above what was measured; the range from low to high includes it.
By their numbers in this assay, from the lowest: compounds 2, 3 and 4 (each within the scatter of the next); then compound 1.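

In this assay the sulfonyl sulfur carries propyl, phenyl or thiophen-2-yl with no step beyond the scatter: no change at the digits printed from compound 3 to compound 4 (within the scatter) and a 1.4-fold higher number from compound 2 to compound 4 (0.14 log units; within the scatter) leave these three substituents unseparated. Within the data shown here, the one step beyond the scatter, a 4.2-fold lower number from compound 1 to compound 4 (0.62 log units; beyond the scatter) with hydrogen in place of methyl on an aromatic carbon, places the difference from compound 1 at that carbon and not on the sulfonyl sulfur. No measurement at hand accounts for either finding.

Open, going by these compounds, is whether a longer chain than propyl, or a substituent bearing an amine or a carboxylic acid, holds the number on the sulfonyl sulfur. Also open, on these data alone, is how groups other than methyl behave on that aromatic carbon.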